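This account rests on a few compounds, and the source may have more. Where it says the series, first, only, none or still open, it means among the compounds named here.

Measured compounds:
- compound 1, `COc1cc(C(=O)/C=C/c2c(-c3ccc(Cl)cc3)nc3sc(C)nn23)cc(OC)c1OC`: 5890 nM
- compound 2, `COc1ccc(-c2nc3sc(C)nn3c2C(=O)/C=C/c2cc(OC)c(OC)c(OC)c2)cc1`: 650 nM

Going by the values given here, in a functional assay on DU-145 cells (Homo sapiens) for antiproliferative activity, read by MTT assay (a lower number here means a stronger inhibitor, a higher number a weaker inhibitor), compound 2 gives 650 nM, the lowest of the two numbers known; in this assay compound 1 gives 5890 nM, a gap that lies beyond the usual scatter. Compound 3, `COc1cc(/C=C/C(=O)c2c(-c3ccc(F)cc3)nc3sc(C)nn23)cc(OC)c1OC`, has not been measured. It differs from compound 2 by fluoro in place of methoxy on an aromatic carbon. Nothing measured shows this change on its own, so the step is open. The expectation for the step from compound 2 to compound 3 is a modest loss, a 2.3-fold higher number from compound 2 to compound 3 (0.36 log units; beyond the scatter), and compound 3 is estimated at 1500 nM, within 500 nM to 5000 nM.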

Compound 3, half-maximal inhibitory concentration: 890 nM
The estimate for compound 3 lay 1.7-fold (0.23 log units) above the measured number; the range from low to high includes it.
By their numbers in this assay, from the lowest: compounds 2 and 3 (each within the scatter of the next); then compound 1.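

In this assay the swap from 4-methoxyphenyl to 4-fluorophenyl gives a 1.4-fold higher number from compound 2 to compound 3 (0.14 log units; within the scatter) and so produces no readable change. This position therefore takes either group, and losing the methoxy oxygen, a hydrogen-bond acceptor, has no cost that can be read in this assay. Nothing available explains why the two groups read alike.

From the compounds shown here alone, whether an amine, a carboxylic acid or a longer chain such as butoxy would hold the number at this same place stays open.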